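The compounds below may be only part of what the source reports. "The series", "measured", "known", "first", "only" and "open" are said of these compounds alone.

Compound 1 `CC(C)=CC(=O)Nc1cccc(Oc2nc(Nc3cccc(C#N)c3)nc3c2CSCC3)c1`: > 50000 nM
Compound 2 `CCC/C=C/C(=O)Nc1cccc(Oc2nc(Nc3ccc(OC)cc3)nc3c2CSCC3)c1`: > 50000 nM

Both entries come from a functional assay on MCF7 cells (Homo sapiens) for antiproliferative activity, read by MTT assay, with a stated time of 72 h; a higher number here means a weaker inhibitor, a lower number a stronger inhibitor. Compound 2 stands at > 50000 nM, which is a limit of the assay and not a number. The same holds for every result so far: the limit of > 50000 nM in this assay, at which 2 of the 2 values shown sit. No exact potency is therefore known for either measured compound.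

Compound 3 `COc1ccc(Nc2nc3c(c(Oc4cccc(NC(=O)C=C(C)C)c4)n2)CSCC3)cc1` differs from compound 2 in one place: 2-methylprop-1-en-1-yl in place of pent-1-en-1-yl on a carbonyl carbon. In words, 2-methylprop-1-en-1-yl takes the place of pent-1-en-1-yl on a carbonyl carbon, whose other neighbour is an amide-type nitrogen.

For the measured compounds named here, no measured pair shows what a swap of this kind does, so no shift beyond the usual scatter is expected in this assay. This expectation rests on compound 2, which reads > 50000 nM, again a limit. The expected change is a number no higher from compound 2 to compound 3 (the limit leaves the size open). Compound 3 will most likely be reported only as a limit as well. For compound 3 the estimated value is 50000 nM, with an expected range from 15000 nM to 100000 nM.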

Compound 3, half-maximal inhibitory concentration: > 50000 nM
Compound 3 ended at the assay's limit; the forecaster's own chance of this, stated with the estimate: 80%; the middle value lies on the limit itself.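

Compound 3, like compound 1 and compound 2, yields no exact number in this assay, so its steps from compound 2 and from compound 1 cannot be read: the limit of > 50000 nM in this assay, at which 3 of the 3 values shown sit.

The compounds shown leave open how potent any of the three really is, and whether either swapped group changes that potency at all.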